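Adding a Second Hydroxy Group to a Phenol Hydrazone

The source may hold more compounds than are shown below. What is called first, only, known or untested is meant among the compounds shown, and "the series" means these compounds.

Compound 1 `O=C(N/N=C/c1cccc(O)c1O)c1ccc(-c2nc3ccccc3s2)cc1`: 11200 nM
Compound 2 `COc1ccc(/C=N/NC(=O)c2ccc(-c3nc4ccccc4s3)cc2)c(O)c1`: 6970 nM
Compound 3 `O=C(N/N=C/c1ccccc1O)c1ccc(-c2nc3ccccc3s2)cc1`: 5550 nM

In an assay on isolated protein for inhibition of Maltase-glucoamylase (Homo sapiens), with a stated time of 15 min (on this read-out lower numbers stand for stronger inhibition and higher numbers for weaker inhibition), compound 3 gives the lowest of the three numbers, though its gaps to compound 2 and compound 1 are both within the scatter. Compound 4 `O=C(N/N=C/c1ccc(O)cc1O)c1ccc(-c2nc3ccccc3s2)cc1` carries a change of hydroxy in place of hydrogen on an aromatic carbon, placed meta to a hydroxy group and para to a large group; read one bond further out, 2-hydroxyphenyl becomes 2,4-dihydroxyphenyl. Among the measured compounds shown here, two measured steps bear on this: a 2.0-fold lower number from compound 1 to compound 3 (0.30 log units; within the scatter) and a 1.3-fold lower number from compound 2 to compound 3 (0.10 log units; within the scatter), each within the scatter. Since neither an extra hydroxy nor a methoxy on this ring moved this assay beyond the scatter, compound 4 is expected to show a 1.3-fold higher number from compound 3 to compound 4 (0.10 log units; within the scatter), no step beyond the scatter. Compound 4 is therefore estimated at 7000 nM, in the range 3000 nM to 16000 nM.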

Compound 4, half-maximal inhibitory concentration: 5580 nM
Compound 4: middle estimate off by 1.3-fold (0.10 log units), on the high side, within the range that was stated.
By their numbers in this assay, from the lowest: compounds 3, 4, 2 and 1 (each within the scatter of the next).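

In this assay the step of a 1.0-fold higher number from compound 3 to compound 4 (0.00 log units; within the scatter) shows that hydroxy in place of hydrogen, on the ring carbon meta to a hydroxy group and para to a large group, leaves the number where it was. The steps of a 1.2-fold lower number from compound 2 to compound 4 (0.10 log units; within the scatter) and a 2.0-fold lower number from compound 1 to compound 4 (0.30 log units; within the scatter) also stay within the scatter, so these four ring patterns cannot be told apart in this assay on these numbers. No measurement available here accounts for this result. From the compounds shown here alone, whether an amine or a carboxylic acid on this ring carbon would also stay within the scatter remains open. So does the outcome for a longer chain, such as butoxy, in that place.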